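The compounds below may be only part of what the source reports. "The series", "measured", "known", "first", "only" and "open" are said of these compounds alone.

Measured so far in an assay on CHO cells for displacement of a labelled ligand from adenosine receptor A1 (Homo sapiens), read by scintillation counting, with a stated time of 120 min, tested at 10 uM; a higher number here means more inhibition at the concentration tested (going by the name of the read-out), a lower number less inhibition:

compound 1 `Nc1scc(CN2CCN(c3cccc(C(F)(F)F)c3)CC2)c1C(=O)c1ccc(Cl)cc1` — 0%
compound 2 `Nc1scc(CN2CCN(C3CCCCCC3)CC2)c1C(=O)c1ccc(Cl)cc1` — 0%
compound 3 `Nc1scc(CN2CCN(c3ccc(F)c(F)c3)CC2)c1C(=O)c1ccc(Cl)cc1` — 0%

Compound 3 stands level with compound 1 and compound 2 in this assay; all three read-outs sit at the floor of the scale, and none of the three is set apart from the others. The substituent on the ring amine nitrogen has been varied across an aryl group bearing trifluoromethyl, a cycloheptyl group and a difluorinated aryl group, with the rest of the shared core held fixed, and each step left the number unchanged: no change at the digits printed from compound 1 to compound 2 (within the scatter), no change at the digits printed from compound 1 to compound 3 (within the scatter) and no change at the digits printed from compound 2 to compound 3 (within the scatter).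

Compound 4 `Nc1scc(CN2CCN(CCCc3ccc(Cl)cc3)CC2)c1C(=O)c1ccc(Cl)cc1` continues this variation at the same position. The change is 3-(4-chlorophenyl)propyl in place of 3,4-difluorophenyl on an amine nitrogen in a ring. The three steps above all bear on it, since each swaps the group on the same ring amine nitrogen, and each was flat within the scatter. Nothing in the series points in either direction, so no step beyond the scatter is expected in this assay; the expected step is no change at the digits printed from compound 3 to compound 4 (within the scatter). Compound 4 is therefore estimated at 0% in this assay, with an expected range from -10% to 12%.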

Compound 4, a percentage reported as inhibition, at one concentration (the size of the read-out at that concentration, not a potency): 0%
The estimate for compound 4 equals the measured number at the digits printed; measured number inside the range.
By their numbers in this assay, from the lowest: compounds 1, 2, 3 and 4 (each within the scatter of the next).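

With the 3-(4-chlorophenyl)propyl group, the first at this place to carry a chain, this assay gives no change at the digits printed from compound 3 to compound 4 (within the scatter) and no change at the digits printed from compound 2 to compound 4 (within the scatter) and also no change at the digits printed from compound 1 to compound 4 (within the scatter) as the steps to compound 4. The group on the amine nitrogen in the ring now spans substituted phenyl rings, cycloheptyl and a chlorophenyl group on a propyl chain, and none of these separates from the others in this assay, so the series still gives no ranking of groups and no direction for this position. No measurement on hand accounts for the flat read-out.

As far as these compounds go, it remains open whether any group at this nitrogen lifts the read-out off the floor of the scale, for example a shorter or longer chain, a chain ending in a hydroxyl, an amide or a carboxylic acid, or a heteroaromatic ring such as pyridine. Also open, from the compounds shown here alone, is whether replacing the primary amine or the chlorine on the shared core would change the picture in this assay at all.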